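This account rests on a few compounds, and the source may have more. Where it says the series, first, only, none or still open, it means among the compounds named here.

Measured so far: compound 1 `CCOC(=O)C1=C(C)NC(=O)NC1c1ccc(O)c(O)c1` gives 1.6 ug/mL; compound 2 `CCOC(=O)C1=C(C)NC(=O)NC1c1ccc(O)cc1` gives 27.3 ug/mL; compound 3 `CCOC(=O)C1=C(C)NC(=S)NC1c1ccc(O)c(OC)c1` gives 11 ug/mL, all in a functional assay on OVCAR-3 cells (Homo sapiens) for inhibition, read by sulforhodamine B assay, with a stated time of 48 h; a lower number here means a stronger inhibitor of growth, a higher number a weaker inhibitor of growth.

Compound 2 stands highest of the three numbers. Its nearest neighbour is compound 3, and the furthest is compound 1, with the step of a 17-fold higher number from compound 1 to compound 2 (1.23 log units; beyond the scatter) being the only one that touches it. Compound 4 `CCCc1ccc(C2NC(=O)NC(C)=C2C(=O)OCC)cc1` differs from compound 2 by propyl in place of hydroxy on an aromatic carbon. For the measured compounds named here, no measured pair shows a propyl entering, so only the large step from compound 1 to compound 2 bears on this change, and only loosely: it shows that taking a hydroxy away weakened growth inhibition. For compound 4 a modest weakening is therefore expected, a 1.5-fold higher number from compound 2 to compound 4 (0.17 log units; within the scatter), with wide uncertainty. The estimate for compound 4 is 40 ug/mL, within 12 ug/mL to 120 ug/mL.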

Compound 4, concentration for 50% growth inhibition: 52.4 ug/mL
Compound 4: middle estimate off by 1.3-fold (0.12 log units), on the low side; the range from low to high includes it.
By their numbers in this assay, from the lowest: compound 1; then compound 3; then compounds 2 and 4 (each within the scatter of the next).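

In this assay, propyl in place of hydroxy on an aromatic carbon, para to a large group, gives a 1.9-fold higher number from compound 2 to compound 4 (0.28 log units; within the scatter), so at this place the two groups cannot be told apart, although the exchange removes the hydroxy with its hydrogen-bond donor and acceptor. For the compounds shown here, the large step of a 17-fold higher number from compound 1 to compound 2 (1.23 log units; beyond the scatter) therefore has no counterpart in this change. Nothing available explains why these two groups read alike. As far as these compounds go, whether an amine, a carboxylic acid or a longer chain at this place would also leave the number within the scatter remains open.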